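The source may hold more compounds than are shown below. What is called first, only, known or untested is meant among the compounds shown, and "the series" means these compounds.

Among the measured compounds shown here, in a functional assay on A549 cells (Homo sapiens) for cytotoxicity, read by WST assay, with a stated time of 24 h (a lower number here means a stronger inhibitor, a higher number a weaker inhibitor), compound 1 (`COc1ccc2c(/C=C(\C#N)C(=O)c3c[nH]c4ccccc34)c[nH]c2c1`) gives 9600 nM and compound 2 (`N#C/C(=C\c1c[nH]c2ccccc12)C(=O)c1c[nH]c2ccccc12`) gives 16100 nM so compound 2 stands level with the only other measured compound. Compound 3 (`COc1ccc2c(C(=O)/C(C#N)=C/c3c[nH]c4ccccc34)c[nH]c2c1`) differs from compound 2 by methoxy in place of hydrogen on an aromatic carbon. For the measured compounds named here, the one measured step bearing on this is the same exchange in the opposite sense at a different aromatic carbon (a 1.7-fold higher number from compound 1 to compound 2 (0.22 log units; within the scatter)) and it is small. No change beyond the scatter is therefore expected in this assay and the estimated step (a 1.5-fold lower number from compound 2 to compound 3 (0.17 log units; within the scatter)) reflects that. For compound 3 the estimated value is 11000 nM with an expected range from 5500 nM to 22000 nM in this measurement.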

Compound 3, half-maximal inhibitory concentration: 6400 nM
Compound 3: middle estimate off by 1.7-fold (0.24 log units), on the high side; the measured number falls inside the stated range.
By their numbers in this assay, from the lowest: compounds 3, 1 and 2 (each within the scatter of the next, the first and the last beyond it).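

In this assay methoxy in place of hydrogen on this aromatic carbon, meta to a fused ring and para to a fused ring, gives a modest step beyond the scatter (a 2.5-fold lower number from compound 2 to compound 3 (0.40 log units; beyond the scatter)). The same exchange at a different aromatic carbon had stayed within the scatter (a 1.7-fold higher number from compound 1 to compound 2 (0.22 log units; within the scatter)), so the position of the methoxy can matter in this assay. No measurement at hand explains this difference.

The compounds shown leave open whether a hydroxyl, an ethoxy chain or a chlorine atom on this carbon would lower the number as methoxy does.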